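Trimming the amide of a naphthyloxyacetamide series

A few compounds are considered here, and "the series" means these few. Any claim that something is new, unique, unknown or untested is made for them only; others in the source may bear on it.

Compound 1 `CN1CCN(C(=O)COc2cccc3ccccc23)CC1` gives 73.8% in a functional assay on the whole organism with Mus musculus as the target, in the elevated plus maze, with a stated time of 24 h, at a dose of 1 mg/kg by the intraperitoneal route (on this read-out higher numbers stand for a stronger effect at the one dose given and lower numbers for a weaker effect), and compound 2 `O=C(COc1cccc2ccccc12)N1CCCCC1` gives 63%. Compound 2 stands lowest of the two numbers measured, its nearest neighbour being compound 1, and the step of a number 10.8 percentage points lower from compound 1 to compound 2 (beyond the scatter) lies beyond the scatter. Compound 3 `CN(C)C(=O)COc1cccc2ccccc12` has not been measured; it differs from compound 2 in one place: dimethylamino in place of piperidin-1-yl on a carbonyl carbon. Going by the values given here, the only measured step that bears on this change is the one from compound 1 to compound 2, which altered the group on the same carbonyl carbon and lowered the read-out by a modest amount. That step points the expectation downward, yet the present change leaves no ring where the earlier one kept a ring, so the direction is uncertain. Compound 3 is expected to give 58% in this assay, with a likely range from 40% to 76%. The estimated step of a number 5 percentage points lower from compound 2 to compound 3 (within the scatter) is thus expected to stay within the scatter.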

Compound 3, a percentage reported as activity, at one dose (the size of the read-out at that dose, not a potency): 52.9%
Compound 3: middle estimate off by 5.1 percentage points, on the high side; low and high end bracket the measured number.
By their numbers in this assay, from the lowest: compound 3; then compound 2; then compound 1.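

In this assay, dimethylamino in place of piperidin-1-yl on the carbonyl carbon gives a number 10.1 percentage points lower from compound 2 to compound 3 (beyond the scatter) and so does not leave the read-out unchanged, which shows that an open group with no ring does not match the six-membered ring at this position. Taken from the 4-methylpiperazin-1-yl amide to the dimethylamino amide, the change gives a number 20.9 percentage points lower from compound 1 to compound 3 (beyond the scatter) and the largest difference among the three compounds, so the group on this carbonyl carbon clearly sets the size of the effect at the one dose given. Nothing available explains this order.

From the compounds shown here alone, it remains open whether a morpholine ring, a pyrrolidine ring or a 4-ethylpiperazine ring on the same carbonyl carbon would extend or break this order. Going by these compounds, it also remains open whether a secondary amide bearing a longer chain would follow the dimethylamino amide.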